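The compounds below may be only part of what the source reports. "The series", "measured", "known", "first", "only" and "open" are said of these compounds alone.

Measured in a toxicity assay on MT4 cells (Homo sapiens) for cytotoxicity, read by MTT assay, with a stated time of 5 days; on this read-out lower numbers stand for higher toxicity in this test and higher numbers for lower toxicity in this test:

Compound 1 `Cc1cnc(Nc2ccc(C#N)cc2)nc1Nc1c(F)cc(-c2cncnc2)cc1F`: 900 nM
Compound 2 `Cc1cnc(Nc2ccc(C#N)cc2)nc1Nc1c(F)cc(-c2cc(F)nc(F)c2)cc1F`: 103000 nM
Compound 3 `Cc1cc(-c2ccnc3ccccc23)cc(C)c1Nc1ccnc(Nc2ccc(C#N)cc2)n1`: 3500 nM

Compound 3, at 3500 nM, holds the middle place of the three numbers. Its gaps to the other two lie beyond the usual scatter, with compound 1 lower and compound 2 higher.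

Compound 4 `Cc1cc(-c2ccnc(F)c2)cc(C)c1Nc1ccnc(Nc2ccc(C#N)cc2)n1` keeps the core of compound 3 and carries 2-fluoropyridin-4-yl in place of quinolin-4-yl on an aromatic carbon.

Among the compounds with values here, no measured step makes this exact exchange. The nearest evidence is a 110-fold higher number from compound 1 to compound 2 (2.06 log units; beyond the scatter), a large step beyond the scatter, in which 2,6-difluoropyridin-4-yl replaces pyrimidin-5-yl. That step rests on a single pair with a different core, a different departing group and a different entering group, so it supports the direction better than the size. In this assay, a rise is therefore expected for compound 4, though a clearly smaller one than that pair showed. The estimated change is a 4.0-fold higher number from compound 3 to compound 4 (0.60 log units; beyond the scatter), and it may not lie far beyond the scatter.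

For compound 4 the expected value is 14000 nM, with an estimated range from 4000 nM to 50000 nM.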

Compound 4, half-maximal cytotoxic concentration: 6000 nM
Compound 4: the middle estimate sits 2.3-fold (0.37 log units) above what was measured; measured number inside the range.
By their numbers in this assay, from the lowest: compound 1; then compounds 3 and 4 (each within the scatter of the next); then compound 2.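

In this assay, the exchange at this position, on an aromatic carbon meta to two methyl groups and para to a large group, gives a 1.7-fold higher number from compound 3 to compound 4 (0.23 log units; within the scatter), a step within the scatter. Quinolin-4-yl, with 10 heavy atoms in two six-membered aromatic rings, thus gives way to 2-fluoropyridin-4-yl, with 7 heavy atoms in one such ring, without a change that this assay can separate from the scatter, whereas the only earlier step, a 110-fold higher number from compound 1 to compound 2 (2.06 log units; beyond the scatter), was large but involved a different core and different groups, so a fluorinated pyridine entering does not bring a step of that size in every setting shown. Nothing measured here bears on why this exchange gives the result it does.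

Going by these compounds, what a plain pyridin-4-yl, a carboxylic acid or an aminomethyl group would give at this same position on the core of compound 3 remains open, so the part played by the fluorine and by the second ring of quinolin-4-yl cannot be told apart. Also open, on these data alone, is whether 2,6-difluoropyridin-4-yl on the core of compound 3 would repeat the large step seen on the core of compound 1.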